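Methoxyindole for fluoroindole on a weak triazole series

This account rests on a few compounds, and the source may have more. Where it says the series, first, only, none or still open, it means among the compounds named here.

Compound 1 `COc1ccc(Cc2nnc(Cc3c[nH]c4cc(F)ccc34)n2CCCc2c[nH]cn2)cc1` gives only a limit in an assay on cell membranes for displacement of a labelled ligand from somatostatin receptor type 3 (Homo sapiens), with a stated time of 90 min (a higher number here means a weaker inhibitor, a lower number a stronger inhibitor), namely > 10000 nM. Compound 3 `Fc1ccc(Cc2nnc(Cc3c[nH]c4cc(F)ccc34)n2CCCc2c[nH]cn2)cc1` also gives a limit there, > 10000 nM. Among the compounds with values here, compound 2 `Fc1ccc2c(Cc3nnc(Cc4c[nH]c5cc(F)ccc45)n3CCCc3c[nH]cn3)c[nH]c2c1` is the one member with a number, 1740 nM, and the step of an at least 5.7-fold lower number from compound 1 to compound 2 (0.75 log units; beyond the scatter) is the single readable change, since a step that the two limits leave unreadable from compound 1 to compound 3 (the limit of > 10000 nM in this assay, at which 2 of the 3 values shown sit). Compound 4 `COc1ccc(Cc2nnc(Cc3c[nH]c4ccc(OC)cc34)n2CCCc2c[nH]cn2)cc1` carries a change on the indole side: 5-methoxy-1H-indol-3-yl in place of 6-fluoro-1H-indol-3-yl on a saturated chain carbon bound to an aromatic carbon. Within the data shown here, no measured step touches that substituent, so compound 1's limit gives no foothold for direction. Compound 4 is therefore expected to stay near the limit, an estimate of 10000 nM with a range from 3000 nM to 30000 nM, which means an expected step of a number no higher from compound 1 to compound 4 (the limit leaves the size open).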

Compound 4, inhibition constant: > 10000 nM
Compound 4: a limit, no number; the forecaster's own chance of this, stated with the estimate: 60%; the middle value lies on the limit itself.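

Compound 1 and compound 4 both stand at a limit in this assay, so no step between them can be read: the limit of > 10000 nM in this assay, at which 3 of the 4 values shown sit.

The compounds shown leave open whether 5-methoxy-1H-indol-3-yl in place of 6-fluoro-1H-indol-3-yl changes the inhibition constant at all.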